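Aryl in place of cyclopentyl on the piperazine amide

The compounds below may be only part of what the source reports. "The series", "measured", "known", "first", "only" and "open" are said of these compounds alone.

Three compounds share one core. In an assay on isolated protein for inhibition of aldehyde dehydrogenase 1A1 (Homo sapiens), read by spectrophotometry, tested at 10 uM (on this read-out higher numbers stand for more inhibition at the one concentration tested (going by the name of the read-out) and lower numbers for less inhibition), compound 2 `Cc1cccc(Cn2c(CN3CCN(C(=O)C4CCCC4)CC3)nc3ccccc32)c1` gives 67.5%, the highest of the three. Compound 3 `O=C(C1CC1)N1CCN(Cc2nc3ccccc3n2Cc2ccccc2F)CC1` gives 40.7%, and compound 1 `Cc1cccc(Cn2c(CN3CCN(C(=O)c4ccc([N+](=O)[O-])cc4)CC3)nc3ccccc32)c1` gives 24.3%. Within the data shown here, the only single-point step recorded, a number 43.2 percentage points higher from compound 1 to compound 2 (beyond the scatter), is large. Compound 4 `Cc1cccc(Cn2c(CN3CCN(C(=O)c4ccc(C(C)C)cc4)CC3)nc3ccccc32)c1` differs from compound 2 by 4-isopropylphenyl in place of cyclopentyl on a carbonyl carbon. This returns a six-membered aromatic ring of carbon only to the carbonyl carbon, as in compound 1, but 4-isopropylphenyl is not 4-nitrophenyl, so that step bears on it only in part. A drop beyond the scatter, smaller than the step between compound 1 and compound 2, is expected. Compound 4 is therefore estimated at 45%, within 22% to 68%. This corresponds to an expected a number 22.5 percentage points lower from compound 2 to compound 4 (beyond the scatter).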

Compound 4, a percentage reported as inhibition, at one concentration (the size of the read-out at that concentration, not a potency): 67.6%
Beside the measured number, compound 4's estimate is 22.6 percentage points below it, and the stated range covers the measured number.
By their numbers in this assay, from the lowest: compound 1; then compound 3; then compounds 2 and 4 (each within the scatter of the next).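

In this assay, an aromatic ring on the carbonyl carbon does not by itself lower the number: a number 0.1 percentage points higher from compound 2 to compound 4 (within the scatter). With that ring kept, a number 43.3 percentage points higher from compound 1 to compound 4 (beyond the scatter), so among these compounds the low value of compound 1 goes with the nitro group and not with the aromatic ring as such. No evidence given here accounts for this difference. The compounds shown leave open whether an unsubstituted phenyl, or an amine or a carboxylic acid in place of the isopropyl, would read like compound 4 or like compound 1.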